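Varying the group on the aromatic carbon: compound 4

A few compounds are considered here, and "the series" means these few. Any claim that something is new, unique, unknown or untested is made for them only; others in the source may bear on it.

Measured so far in an assay (strain Wistar) for inhibition of Hormone-sensitive lipase (Rattus norvegicus), read by spectrophotometry; a higher number here means a weaker inhibitor, a lower number a stronger inhibitor:
Compound 1 `Cc1c(C)n(C(=O)N2CCCCC2)oc1=O` gives 13 nM.
Compound 2 `CCc1c(C)n(C(=O)N2CCCCC2)oc1=O` gives 18 nM in this assay.
Compound 3 `Cc1c(C(C)(C)C)c(=O)on1C(=O)N1CCCCC1` gives 14 nM in this assay.

Compound 1 has the lowest of the three numbers, but the gap to compound 3 and to compound 2 is within the scatter, so the three compounds cannot be ordered. The step to compound 4 `Cc1c(C2CCSCC2)c(=O)on1C(=O)N1CCCCC1` is thian-4-yl in place of methyl on an aromatic carbon. Within the data shown here, two measured steps bear on this position. Replacing methyl by tert-butyl gave a 1.1-fold higher number from compound 1 to compound 3 (0.03 log units; within the scatter), and replacing ethyl by tert-butyl gave a 1.3-fold lower number from compound 2 to compound 3 (0.11 log units; within the scatter); the chain extension elsewhere, a 1.4-fold higher number from compound 1 to compound 2 (0.14 log units; within the scatter), also stayed within the scatter. A six-membered ring at this carbon goes beyond what has been tested, and the sulfur acceptor is new to the series, so the comparison is loose. On the measured steps, no change beyond the scatter is expected for compound 4, giving an estimated step of a 1.2-fold higher number from compound 1 to compound 4 (0.06 log units; within the scatter). Compound 4 is therefore expected to give about 15 nM, with a range from 6 nM to 40 nM.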

Compound 4, half-maximal inhibitory concentration: 11 nM
The estimate for compound 4 lay 1.4-fold (0.13 log units) above the measured number, within the range that was stated.
By their numbers in this assay, from the lowest: compounds 4, 1, 3 and 2 (each within the scatter of the next).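

In this assay, thian-4-yl on this aromatic carbon brings in a six-membered non-aromatic ring with a sulfur atom and a hydrogen-bond acceptor, yet all three new steps stay within the scatter (a 1.2-fold lower number from compound 1 to compound 4 (0.07 log units; within the scatter); a 1.3-fold lower number from compound 3 to compound 4 (0.10 log units; within the scatter); a 1.6-fold lower number from compound 2 to compound 4 (0.21 log units; within the scatter)). Among these compounds, the flat picture at this carbon, so far seen only with open-chain groups from methyl to tert-butyl, therefore also holds for a group of 6 heavy atoms containing a ring. No measurement bears on why the number stays flat across these groups.

Going by these compounds, whether an amine, a carboxylic acid or a phenyl ring on this carbon would move the number beyond the scatter remains open. Also open, on these data alone, is how the number responds when a morpholine ring replaces the piperidine ring shared by all four compounds.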